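The source may report more compounds than this note shows. Statements on the series, on what has been measured and on what is new or still open speak of the compounds shown alone.

Going by the values given here, in a functional assay on U-251 cells (Homo sapiens) for cytotoxicity, read by sulforhodamine B assay, with a stated time of 48 h (on this read-out higher numbers stand for weaker inhibition and lower numbers for stronger inhibition), two compounds sharing one core have numbers so far. Compound 1 (`O=C(c1ccc2nc(NC(=O)C(F)(F)F)cn2c1)c1ccc(C(F)(F)F)cc1F`) gives 52300 nM, and compound 2 (`Cc1ccc(F)c(C(=O)c2ccc3nc(NC(=O)C(F)(F)F)cn3c2)c1`) gives 84200 nM. These two values lie within the usual scatter of each other, so compound 2 cannot be told apart from compound 1 on this read-out.

Compound 3 (`O=C(c1ccc2nc(NC(=O)C(F)(F)F)cn2c1)c1cc(C(F)(F)F)ccc1F`) comes from compound 2 by a single change: trifluoromethyl in place of methyl on an aromatic carbon. Among the compounds with values here, no measured pair isolates this swap, so its size cannot be read directly from the data. Within the data shown here, the one guide is compound 1, which also carries a trifluoromethyl group and gives 52300 nM, so no step beyond the scatter is expected in this assay. The estimated move is a 1.4-fold lower number from compound 2 to compound 3 (0.15 log units; within the scatter). For compound 3 the expected value is 60000 nM, with an estimated range from 25000 nM to 130000 nM.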

Compound 3, half-maximal inhibitory concentration: 51900 nM
The estimate for compound 3 lay 1.2-fold (0.06 log units) above the measured number; the measured number falls inside the stated range.
By their numbers in this assay, from the lowest: compounds 3, 1 and 2 (each within the scatter of the next).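

In this assay, going by these compounds alone, this is the first direct look at the swap of methyl for trifluoromethyl on this aromatic carbon, para to a fluoro group, and it gives a 1.6-fold lower number from compound 2 to compound 3 (0.21 log units; within the scatter) as the measured step. Although the entering group has 4 heavy atoms in place of 1, the two compounds cannot be told apart on this read-out, so this single swap at this position produces no detectable change here. Nothing measured here explains why the numbers stay within the scatter of each other.

Going by these compounds, what an amine, a carboxylic acid or a longer chain on this same aromatic carbon would do to the number remains open. On these data alone, it is also open whether the swap of methyl for trifluoromethyl would look the same on a ring without the fluoro group.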